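Trimming the hydrazone substituent of compound 2 to a methylene

A few compounds are considered here, and "the series" means these few. Any claim that something is new, unique, unknown or untested is made for them only; others in the source may bear on it.

Two hydrazones sharing a benzyl-substituted core have been measured. Compound 1 `Clc1ccccc1/C=N/Nc1nc2ccccc2nc1Cc1ccccc1` gives 5.8 nM in an assay on isolated protein for inhibition of Amine oxidase [flavin-containing] A (Homo sapiens), read by spectrophotometry; a lower number here means a stronger inhibitor, a higher number a weaker inhibitor. Compound 2 `C/C(=N\Nc1nc2ccccc2nc1Cc1ccccc1)c1ccccn1` gives 91 nM in this assay, the higher of the two numbers, with the step of a 16-fold higher number from compound 1 to compound 2 (1.20 log units; beyond the scatter) lying beyond the scatter. Compound 3 `C=NNc1nc2ccccc2nc1Cc1ccccc1` carries the change (a group of 2 heavy atoms (1 carbon, 1 nitrogen; no ring) in place of a group of 9 heavy atoms (7 carbon, 2 nitrogen; one six-membered aromatic ring with 1 hetero atom), on a nitrogen on an aromatic ring), a group of 2 heavy atoms (1 carbon, 1 nitrogen; no ring) in place of a group of 9 heavy atoms (7 carbon, 2 nitrogen; one six-membered aromatic ring with 1 hetero atom). Within the data shown here, only one step bears on this, and only indirectly: the exchange of one aromatic ring for another in the step of a 16-fold higher number from compound 1 to compound 2 (1.20 log units; beyond the scatter) was large, showing the read-out is sensitive to what sits at this nitrogen. Removing the ring altogether is expected to raise the number further, with the step of a 6.6-fold higher number from compound 2 to compound 3 (0.82 log units; beyond the scatter) expected. The estimate for compound 3 in this assay is 600 nM, within 120 nM to 3000 nM.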

Compound 3, half-maximal inhibitory concentration: 86 nM
Compound 3: middle estimate off by 7.0-fold (0.84 log units), on the high side; the whole stated range lies above it.
By their numbers in this assay, from the lowest: compound 1; then compounds 3 and 2 (each within the scatter of the next).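

In this assay, the group holding the six-membered aromatic ring with 1 hetero atom in compound 2 gives way to the ringless group of compound 3 with a 1.1-fold lower number from compound 2 to compound 3 (0.02 log units; within the scatter), so an aromatic ring at this position is not required to reach this level of inhibition. Against the chlorine-bearing group, the ringless group gives a 15-fold higher number from compound 1 to compound 3 (1.17 log units; beyond the scatter), which sets compound 1 apart from both other compounds, whose groups are very different in size. No available evidence bears on why these groups compare in this way.

The compounds shown do not separate the chlorine from the carbon-only aromatic ring in compound 1; an unsubstituted phenyl or a fluorine in place of the chlorine would address this. Going by these compounds, how a primary amine or a longer alkyl chain would read at this position also remains open.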